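The source may report more compounds than this note shows. Statements on the series, on what has been measured and on what is new or still open speak of the compounds shown alone.

Measured so far:
- compound 1, `O=C(NNC(=O)c1ccccc1Br)c1ccc(-n2cccc2)cc1`: 201000 nM
- compound 2, `Clc1ccc(-c2nnc(-c3ccc(-n4cccc4)cc3)o2)cc1`: 256000 nM
- compound 3, `CC(=O)N1N=C(c2ccc(-n3c(C)ccc3C)cc2)OC1c1ccccc1[N+](=O)[O-]`: 182000 nM

All three have been run in an ADME assay on A549 cells (Homo sapiens) for cytotoxicity, read by MTT assay, with a stated time of 72 h; on this read-out higher numbers stand for weaker inhibition and lower numbers for stronger inhibition. Compound 1 gives 201000 nM, compound 2 gives 256000 nM and compound 3 gives 182000 nM. Compound 2 carries the nominally highest of the three numbers, yet its gap to compound 1 and its gap to compound 3 each lie within the usual scatter, so on this read-out the three compounds cannot be told apart, and none of them is a weak or strong inhibitor relative to the others. Among the measured compounds shown here, no two of the measured compounds differ in a single place, so no measured step is available as a guide.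

Compound 4 is `Brc1ccc(-c2nnc(-c3ccc(-n4cccc4)cc3)o2)cc1`. Relative to compound 2 the change is bromo in place of chloro on an aromatic carbon. For the measured compounds named here, with no measured step of this kind on hand, and with all three measured numbers sitting together, the expectation in this assay is a step of no size beyond the scatter, in either direction; the estimated step is a 1.1-fold lower number from compound 2 to compound 4 (0.03 log units; within the scatter). Compound 4 is therefore expected to give about 240000 nM, with an estimated range from 120000 nM to 480000 nM.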

Compound 4, half-maximal inhibitory concentration: 264000 nM
Estimate against measurement, compound 4: 1.1-fold (0.04 log units) below; the range from low to high includes it.
By their numbers in this assay, from the lowest: compounds 3, 1, 2 and 4 (each within the scatter of the next).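

In this assay, among the compounds shown here, the exchange of 4-chlorophenyl for 4-bromophenyl (a 1.0-fold higher number from compound 2 to compound 4 (0.01 log units; within the scatter)) is the only comparison so far that isolates a single place, an aromatic carbon para to a large group, with the rest of the structure held fixed. The earlier compounds shown here differ from one another in more than one place and could not speak to this position alone, whereas this pair shows that chloro and bromo cannot be told apart here on this read-out. No measurement at hand bears on why the pair reads this way.

One exchange of one halogen for another says little about the reach of this position, and a carboxylic acid, an amine or a methoxy group on the same aromatic carbon would test it more sharply. Also open, as far as these compounds go, is whether a single change elsewhere on the shared core, such as an added ethyl chain, would give a step beyond the scatter in this assay at all.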